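The source may hold more compounds than are shown below. What is called first, only, known or untested is meant among the compounds shown, and "the series" means these compounds.

Of the compounds shown here, two have been measured in an assay on isolated protein for inhibition of RAC-alpha serine/threonine-protein kinase (Homo sapiens), tested at 30 uM; on this read-out higher numbers stand for more inhibition at the one concentration tested (going by the name of the read-out) and lower numbers for less inhibition. Compound 1, `Fc1ccc(Sc2ncnc3[nH]cnc23)cc1`, carries a (4-fluorophenyl)sulfanyl group on its core, and in this assay compound 1 gives 0%. Compound 2, `Clc1ncnc2c1ncn2Cc1ccccc1`, carries a chloro group on a core that also bears a benzyl group, and in this assay compound 2 gives 0%. On these numbers compound 2 stands level with compound 1: the two readings differ by nothing at the digits shown, which lies within the scatter, so no order between them can be drawn.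

Compound 3, `Fc1ccc(Sc2ncnc3c2ncn3Cc2ccccc2)cc1`, has not yet been measured. It differs from compound 2 in one place: (4-fluorophenyl)sulfanyl in place of chloro on an aromatic carbon. Within the data shown here, the group that enters is the one that compound 1 already carries, and compound 1 shows 0% in this assay, while compound 2 with the chloro shows 0%. Since neither measured compound shows inhibition, the step is expected to be a number 5 percentage points higher from compound 2 to compound 3 (within the scatter), that is, none beyond the scatter. Compound 3 is therefore estimated to give 5% in this assay, within a range from 0% to 25%.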

Compound 3, a percentage reported as inhibition, at one concentration (the size of the read-out at that concentration, not a potency): 1%
The estimate for compound 3 lay 4 percentage points above the measured number; measured number inside the range.
By their numbers in this assay, from the lowest: compounds 1, 2 and 3 (each within the scatter of the next).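

In this assay, (4-fluorophenyl)sulfanyl in place of chloro on this aromatic carbon of the benzyl-bearing core leaves the reading within the scatter (a number 1 percentage points higher from compound 2 to compound 3 (within the scatter)), so swapping a single chlorine for this much larger group with its aromatic ring brings no measurable inhibition at this position. Seen from the other side, benzyl in place of hydrogen on the aromatic nitrogen also stays within the scatter (a number 1 percentage points higher from compound 1 to compound 3 (within the scatter)), which shows what the earlier compounds could not: the two groups carried together on one core give no reading that stands apart from those of compounds with only one of them. Nothing on hand explains why all these readings stay so close to zero.

Among these compounds, with every reading this low, the series gives no order among the compounds and no sign of whether either change helps or harms, so neither group can be credited or blamed. As far as these compounds go, it remains open whether an amine, a carboxylic acid or a longer chain on this aromatic carbon, in place of the (4-fluorophenyl)sulfanyl group, would lift the reading clear of the scatter.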